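Methoxy in Place of Methyl on Compound 2

The compounds below may be only part of what the source reports. "The series", "measured", "known", "first", "only" and "open" are said of these compounds alone.

Compound 1 `COc1ccc(-c2nnc(NC(=O)/C=C/c3ccc(F)cc3)s2)cc1`: 0.85 ug/mL
Compound 2 `Cc1ccc(-c2nnc(NC(=O)/C=C/c3ccccc3)s2)cc1`: 1.19 ug/mL

Both compounds were tested in a functional assay on MCF7 cells (Homo sapiens) for antiproliferative activity, read by MTT assay, with a stated time of 48 h; on this read-out lower numbers stand for stronger inhibition and higher numbers for weaker inhibition. There, compound 2 gives 1.19 ug/mL and compound 1 gives 0.85 ug/mL, and these two values lie within the scatter of each other, so the two cannot be ranked. For the measured compounds named here, the two also differ in more than one place, so no measured step isolates a single change.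

Compound 3 `COc1ccc(-c2nnc(NC(=O)/C=C/c3ccccc3)s2)cc1` is still to be measured. It departs from compound 2 by methoxy in place of methyl on an aromatic carbon, para to a large group: methoxy in place of methyl on an aromatic carbon. Compound 1 already carries the 4-methoxyphenyl and gives 0.85 ug/mL, so no step beyond the scatter is expected. The expected change is a 1.2-fold lower number from compound 2 to compound 3 (0.08 log units; within the scatter). The estimated value for compound 3 is 1 ug/mL, with an expected range from 0.4 ug/mL to 2.5 ug/mL.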

Compound 3, half-maximal inhibitory concentration: 0.78 ug/mL
For compound 3 the middle estimate is 1.3-fold (0.11 log units) above the measured one; low and high end bracket the measured number.
By their numbers in this assay, from the lowest: compounds 3, 1 and 2 (each within the scatter of the next).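

In this assay, the change from 4-methylphenyl to 4-methoxyphenyl now has a measured step that isolates it, a 1.5-fold lower number from compound 2 to compound 3 (0.18 log units; within the scatter), so on this aromatic carbon, para to a large group, methoxy and methyl cannot be told apart. Compound 3 also isolates the fluoro of compound 1, with hydrogen in its place giving a 1.1-fold lower number from compound 1 to compound 3 (0.04 log units; within the scatter), so that change cannot be told apart from the scatter either. Nothing at hand bears on why either step is this small.

The compounds shown leave open whether a different group at this position, such as an amine, a carboxylic acid or a longer chain like butoxy, would move the number beyond the scatter. They also leave open whether a group other than fluoro, such as a nitrile, would do so in place of that hydrogen.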